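Swapping the Aryl Group of a Cholesterol Acyltransferase Inhibitor

The source may hold more compounds than are shown below. What is called first, only, known or untested is meant among the compounds shown, and "the series" means these compounds.

Of the compounds shown here, three have so far been measured in an assay on microsomes from intestine for inhibition of acyl-CoA:cholesterol acyltransferase (Oryctolagus cuniculus); a higher number here means a weaker inhibitor, a lower number a stronger inhibitor. Compound 1 `CC(C)c1cccc(C(C)C)c1NC(=O)NCc1ccccc1` gives 360 nM. Compound 2 `Cc1ccccc1NC(=O)NCC1(c2ccccc2)CCCCC1` gives 640 nM, the highest number of the three; compound 1 sits within the usual scatter of it, whereas compound 3 `O=C(NCC1(c2ccccc2)CCCCC1)Nc1ccccc1C(F)(F)F`, with 200 nM, lies clearly beyond it. Among the measured compounds shown here, the step of a 3.2-fold lower number from compound 2 to compound 3 (0.51 log units; beyond the scatter) is the only measured change on the aryl group attached to the amide-type nitrogen of the shared core.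

Compound 4 `O=C(NCC1(c2ccccc2)CCCCC1)Nc1ccc(Cl)cc1` differs from compound 2 in one place: 4-chlorophenyl in place of 2-methylphenyl on an amide-type nitrogen. For the measured compounds named here, no measured pair covers this exact exchange. Going by the values given here, the single step on the same ring, a 3.2-fold lower number from compound 2 to compound 3 (0.51 log units; beyond the scatter), was modest, so a change of similar size at most seems reasonable; its direction, however, cannot be read from the data, since that step only altered a group rather than exchanging the whole aryl unit. Compound 4 is therefore expected to give about 700 nM in this assay, with a range from 250 nM to 2000 nM. This estimate means a step of a 1.1-fold higher number from compound 2 to compound 4 (0.04 log units; within the scatter), which is not expected to go beyond the scatter.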

Compound 4, half-maximal inhibitory concentration: 2200 nM
For compound 4 the middle estimate is 3.1-fold (0.50 log units) below the measured one; the measured number lies above the stated range.
By their numbers in this assay, from the lowest: compounds 3, 1 and 2 (each within the scatter of the next, the first and the last beyond it); then compound 4.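

In this assay, exchanging the aryl group on the amide-type nitrogen can raise the number as well as lower it: a 3.4-fold higher number from compound 2 to compound 4 (0.54 log units; beyond the scatter), whereas the earlier change on this ring gave a 3.2-fold lower number from compound 2 to compound 3 (0.51 log units; beyond the scatter). This position therefore responds in both directions, and 4-chlorophenyl gives a weaker inhibitor than 2-methylphenyl even though both groups have the same count of heavy atoms and neither has any hydrogen-bond donors or acceptors. Nothing measured here accounts for this rise.

The exchange alters both the group on the ring and where that group sits, so the two cannot yet be told apart; a chlorine where compound 2 carries its methyl, or a methyl where compound 4 carries its chlorine, would separate them. Also open, going by these compounds, is how the number would respond to a methoxy group or a carboxylic acid on this ring.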